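Swapping the aryl group on the anilino nitrogen: compound 2 to compound 4

The source may hold more compounds than are shown below. What is called first, only, known or untested is meant among the compounds shown, and "the series" means these compounds.

Compound 1, `Cc1ccc(Nc2cc(NC(=O)Nc3c(Cl)cccc3Cl)ncn2)cc1F`: 45.3%
Compound 2, `CCc1ccc(Nc2cc(NC(=O)Nc3cc(OC)cc(OC)c3)ncn2)cc1`: 32.7%
Compound 3, `Cc1cc(F)cc(Nc2cc(NC(=O)Nc3c(Cl)cccc3Cl)ncn2)c1`: 65.1%

All three were tested in a functional assay on NCI-H1581 cells (Homo sapiens) for inhibition, read by MTT assay, with a stated time of 48 h, tested at 10 uM; a lower number here means less inhibition, a higher number more inhibition at the concentration tested (going by the name of the read-out). Among them compound 2 stands lowest, with compound 1 its nearest neighbour and compound 3 furthest away, both gaps beyond the scatter. Compound 4, `COc1cc(NC(=O)Nc2cc(Nc3cccc(C(C)(C)C)c3)ncn2)cc(OC)c1`, differs from compound 2 in one place: 3-(tert-butyl)phenyl in place of 4-ethylphenyl on a nitrogen on an aromatic ring. Among the measured compounds shown here, no measured pair shows exactly this swap. For the measured compounds named here, the only measured step, a number 19.8 percentage points higher from compound 1 to compound 3 (beyond the scatter), also exchanged the aryl group on the same nitrogen and raised inhibition modestly. On that basis a modest rise is expected for compound 4, a number 12.3 percentage points higher from compound 2 to compound 4 (beyond the scatter). Compound 4 is therefore estimated at 45%, most likely between 25% and 65%.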

Compound 4, a percentage reported as inhibition, at one concentration (the size of the read-out at that concentration, not a potency): 35.1%
The estimate for compound 4 lay 9.9 percentage points above the measured number; low and high end bracket the measured number.
By their numbers in this assay, from the lowest: compounds 2 and 4 (each within the scatter of the next); then compound 1; then compound 3.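

The swap seen in a number 2.4 percentage points higher from compound 2 to compound 4 (within the scatter) leaves the read-out in this assay unchanged within the scatter, so replacing 4-ethylphenyl with 3-(tert-butyl)phenyl on this nitrogen has no readable effect. A change of aryl group here therefore does not always move the number, whereas a number 19.8 percentage points higher from compound 1 to compound 3 (beyond the scatter) shows a step beyond the scatter, in a pair that differs from these two elsewhere in the structure. The data at hand offer no explanation for this difference.

As far as these compounds go, it remains open whether an aryl group carrying an amine or a carboxylic acid would shift inhibition at this nitrogen.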